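Hydrazone Ureas: Hydroxy in Place of Dimethylamino

The source may hold more compounds than are shown below. What is called first, only, known or untested is meant among the compounds shown, and "the series" means these compounds.

Compound 1 `COc1ccc(/C=N/NC(=O)Nc2ccc(Oc3ccnc4cc(OCCCN5CCCCC5)c(OC)cc34)c(F)c2)cc1` gives 840 nM in a functional assay on MDA-MB-231 cells (Homo sapiens) for cytotoxicity, read by MTT assay, with a stated time of 72 h; a lower number here means a stronger inhibitor, a higher number a weaker inhibitor. Compound 2 `COc1cc2c(Oc3ccc(NC(=O)N/N=C/c4ccc(N(C)C)cc4)cc3F)ccnc2cc1OCCCN1CCCCC1` gives 1400 nM in this assay.

Compound 2 stands with the higher of these two numbers. Going by the values given here, the only measured step, a 1.7-fold higher number from compound 1 to compound 2 (0.22 log units; within the scatter), stays within the scatter. Compound 3 `COc1cc2c(Oc3ccc(NC(=O)N/N=C/c4ccc(O)cc4)cc3F)ccnc2cc1OCCCN1CCCCC1` differs from compound 2 by hydroxy in place of dimethylamino on an aromatic carbon. Among the compounds with values here, no measured step covers this exact change; the one step known concerned the same position and did not reach beyond the scatter, so no step beyond the scatter is expected in this assay. Compound 3 is therefore estimated at 1100 nM (range 450 nM to 2700 nM), which is expected to mean a 1.3-fold lower number from compound 2 to compound 3 (0.10 log units; within the scatter).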

Compound 3, half-maximal inhibitory concentration: 790 nM
For compound 3 the middle estimate is 1.4-fold (0.14 log units) above the measured one, within the range that was stated.
By their numbers in this assay, from the lowest: compounds 3, 1 and 2 (each within the scatter of the next).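

Hydroxy in place of dimethylamino at this position, para to a large group, gives a 1.8-fold lower number from compound 2 to compound 3 (0.25 log units; within the scatter) in this assay, and hydrogen in place of methyl on the oxygen gives a 1.1-fold lower number from compound 1 to compound 3 (0.03 log units; within the scatter). Methoxy, dimethylamino and hydroxy thus all lie within the scatter of one another here, even though hydroxy brings a hydrogen-bond donor where dimethylamino has none. Nothing available explains why these three groups read alike. Still open, on these data alone, is whether a carboxylic acid, an amine with a longer chain or a halogen at this position would give a step beyond the scatter.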